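The source may report more compounds than this note shows. Statements on the series, on what has been measured and on what is new or still open speak of the compounds shown alone.

Three compounds built on one shared core have been examined in a functional assay on A549 cells (Homo sapiens) for inhibition, read by MTT assay, with a stated time of 72 h; a lower number here means a stronger inhibitor, a higher number a weaker inhibitor. Compound 1 `COc1cc2c(Oc3ccc(NC(=O)c4nn(-c5ccccc5)c(=O)cc4C)cc3F)ccnc2cc1OCCCN1CCCC1` gives 370 nM in this assay. Compound 2 `Cc1cc(=O)n(-c2ccccc2)nc1C(=O)Nc1ccc(Oc2ccnc3cc(OCCCN4CCC(C)CC4)ccc23)c(F)c1` gives 320 nM in this assay, a number within the scatter of that of compound 1, though the two structures differ in two places. Compound 3 `COc1cc2c(Oc3ccc(NC(=O)c4nn(-c5ccccc5C)c(=O)cc4C)cc3F)ccnc2cc1OCCCN1CCCC1` gives 1300 nM in this assay, the highest number of the three: the change a 3.5-fold higher number from compound 1 to compound 3 (0.55 log units; beyond the scatter) sets it apart from compound 1, and its gap to compound 2 is likewise beyond the scatter.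

Compound 4 `COc1cc2c(Oc3ccc(NC(=O)c4nn(-c5ccccc5C)c(=O)cc4C)cc3F)ccnc2cc1OCCCN1CCC(C)CC1` has not yet been measured. It differs from compound 3 by 4-methylpiperidin-1-yl in place of pyrrolidin-1-yl on a saturated chain carbon, three bonds along the chain from an oxygen on an aromatic ring. Among the measured compounds shown here, no measured pair isolates exactly this change. The nearest information comes from compound 1 and compound 2, which differ in this same way and in one further place, and whose numbers in this assay fall within the scatter of each other. On that basis compound 4 is expected to stay close to compound 3, with a step of a 1.2-fold lower number from compound 3 to compound 4 (0.07 log units; within the scatter) that is estimated to remain within the usual scatter. For compound 4 the estimated value in this assay is 1100 nM, with a range from 450 nM to 2800 nM.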

Compound 4, half-maximal inhibitory concentration: 1460 nM
Beside the measured number, compound 4's estimate is 1.3-fold (0.12 log units) below it; the measured number falls inside the stated range.
By their numbers in this assay, from the lowest: compounds 2 and 1 (each within the scatter of the next); then compounds 3 and 4 (each within the scatter of the next).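

Among the compounds shown here, the step of a 1.1-fold higher number from compound 3 to compound 4 (0.05 log units; within the scatter) in this assay gives the first reading of this exchange in one place alone, since compound 1 and compound 2 differ in a second place as well. At this position, on a saturated chain carbon, three bonds along the chain from an oxygen on an aromatic ring, the larger 4-methylpiperidin-1-yl and the smaller pyrrolidin-1-yl cannot be told apart in this assay, even with the aromatic methyl of compound 3 present in both compounds. The earlier step of a 3.5-fold higher number from compound 1 to compound 3 (0.55 log units; beyond the scatter) therefore remains the only change shown here that moves the number beyond the scatter, and nothing available bears on the reason for either result.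

As far as these compounds go, whether this indifference extends to a different kind of terminal group, such as morpholin-4-yl, a carboxylic acid or an open-chain dimethylamino group, remains open. So does the effect of a shorter or longer chain between the oxygen and the terminal ring, and the separate contribution of the further place in which compound 1 and compound 2 differ.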